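The compounds below may be only part of what the source reports. "The series", "measured", "known", "first", "only" and "open" are said of these compounds alone.

The measured compounds and their numbers in a functional assay on HTB-54 cells (Homo sapiens) for cytotoxicity, read by MTT assay, with a stated time of 72 h; on this read-out lower numbers stand for stronger inhibition of growth and higher numbers for weaker inhibition of growth:

Compound 1 `C[Se]c1nc(N)c2ccccc2n1` gives 18000 nM.
Compound 2 `CCCCC[Se]c1nc(NCc2ccc(SC)cc2)c2ccccc2n1` gives 40400 nM.
Compound 3 `CCCCC[Se]c1nc(NCc2ccccc2)c2ccccc2n1` gives 37700 nM.

Compound 3 stands second highest of the three numbers. Among the compounds with values here, its nearest neighbour is compound 2, and the one measured step, a 1.1-fold lower number from compound 2 to compound 3 (0.03 log units; within the scatter), lies within the scatter, so these two compounds cannot be told apart. Within the data shown here, the furthest number is that of compound 1, whose lower value lies beyond the scatter of compound 3; no single-point step joins these two compounds, since they differ in two places.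

Compound 4 `CCCCC[Se]c1nc(N)c2ccccc2n1` arises from compound 3 by the change (hydrogen in place of benzyl on a nitrogen on an aromatic ring). Among the measured compounds shown here, no measured step covers this change: the only step at hand, from compound 2 to compound 3, concerns a different position and was within the scatter. What the numbers show is that compound 1, which also carries an amino group, sits lower than compound 3, but it differs in the selenium chain too, so that comparison is indirect.

On this basis the step of a 1.5-fold lower number from compound 3 to compound 4 (0.18 log units; within the scatter) is expected to be modest, leaning towards a lower number. Compound 4 is therefore estimated at 25000 nM, with a range from 12000 nM to 50000 nM.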

Compound 4, concentration for 50% growth inhibition: 34600 nM
For compound 4 the middle estimate is 1.4-fold (0.14 log units) below the measured one; the range from low to high includes it.
By their numbers in this assay, from the lowest: compounds 1, 4, 3 and 2 (each within the scatter of the next, the first and the last beyond it).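

In this assay, the step of a 1.1-fold lower number from compound 3 to compound 4 (0.04 log units; within the scatter) lies within the scatter, so at this position, on a nitrogen on an aromatic ring, benzylamino and amino cannot be told apart, and the benzyl group as a whole proves no more readable here than the methylsulfanyl group on it did. Compound 4 also gives the first single-place comparison for the chain on selenium: the step of a 1.9-fold higher number from compound 1 to compound 4 (0.28 log units; within the scatter), with butyl in place of hydrogen on a saturated chain carbon bound to a selenium atom, likewise lies within the scatter, so neither single change shown here can be read as a real difference on its own. No supporting information bears on why these steps are as small as they are.

The compounds shown leave open whether a different group on that nitrogen, such as a benzyl carrying a carboxylic acid or a chain ending in an amine, would give a step beyond the scatter. Within the data shown here, they also leave open whether a chain longer than the one in compound 4, or a hydroxyl group at its end, would do so at the selenium.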